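Fluoro to methoxy on the aromatic ring of compound 3

The source may report more compounds than this note shows. Statements on the series, on what has been measured and on what is new or still open speak of the compounds shown alone.

Values in a functional assay (aorta) with Oryctolagus cuniculus as the target (a lower number here means a stronger inhibitor, a higher number a weaker inhibitor), are:
- compound 1 `CC1=C(C)C(=O)C(C(CCCCCCCC(=O)O)c2ccccc2)=C(C)C1=O` gives 3400 nM
- compound 2 `CC1=C(C(CCCCCC(=O)O)c2ccccc2)C(=O)c2ccccc2C1=O` gives 240 nM
- compound 3 `CC1=C(C)C(=O)C(C(CCCCCC(=O)O)c2ccc(F)cc2)=C(C)C1=O` gives 48 nM

Compound 3 has the lowest number of the three, and both others lie above it beyond the scatter. Compound 4 `COc1ccc(C(CCCCCC(=O)O)C2=C(C)C(=O)C(C)=C(C)C2=O)cc1` carries methoxy in place of fluoro on an aromatic carbon, para to a large group: methoxy in place of fluoro on an aromatic carbon. For the measured compounds named here, no measured pair isolates a change at this place. A modest upward step in this assay is therefore expected, possibly none beyond the scatter. The estimated change is a 1.5-fold higher number from compound 3 to compound 4 (0.16 log units; within the scatter). For compound 4 the expected value is 70 nM, with an estimated range from 18 nM to 270 nM.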

Compound 4, half-maximal inhibitory concentration: 3000 nM
The estimate for compound 4 lay 43-fold (1.63 log units) below the measured number, outside the stated range (above it).
By their numbers in this assay, from the lowest: compound 3; then compound 2; then compounds 4 and 1 (each within the scatter of the next).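

In this assay, for the compounds shown here, the change from 4-fluorophenyl to 4-methoxyphenyl gives a 63-fold higher number from compound 3 to compound 4 (1.80 log units; beyond the scatter) and provides the first single-place comparison. The aromatic carbon para to a large group is therefore sensitive to substitution, and the low number of compound 3 does not carry over to methoxy. Nothing available explains the size of this step. Still open, going by these compounds, is how chloro, hydroxy or an amine would read at this place. A single pair also leaves open whether fluoro or methoxy is the outlier among such groups.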